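The compounds below may be only part of what the source reports. "The series", "measured", "known", "first", "only" and "open" are said of these compounds alone.

Compound 2 `CC(=O)c1ccc(N2CCN(C(=O)c3oc(C)nc3-c3ccccc3)CC2)cc1` carries an oxazole-type core that is shared with compound 3 `Cc1ccc(C)c(N2CCN(C(=O)c3oc(C)nc3-c3ccc(Cl)cc3)CC2)c1` and with the unmeasured compound 4 `Cc1nc(-c2ccccc2)c(C(=O)N2CCN(c3cccc(F)c3)CC2)o1`. In a functional assay on HL-60 cells (Homo sapiens) for inhibition, read by MTT assay, with a stated time of 72 h (a higher number here means a weaker inhibitor, a lower number a stronger inhibitor), compound 2 gives "not active" (no number reported), so no single number describes where it stands. Compound 3 likewise gives "not active" (no number reported) in this assay. Within the data shown here, the only compound here with a number is compound 1 `COc1cc(OC)cc(N2CCN(C(=O)c3onc(C)c3-c3ccccc3)CC2)c1`, which has a different core and gives 152 nM in this assay; since its structure differs in more than one place, it cannot be set against compound 2 directly.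

The change from compound 2 to compound 4 is 3-fluorophenyl in place of 4-acetylphenyl on an amine nitrogen in a ring. Among the measured compounds shown here, no measured pair shows the effect of this change, so its size in this assay is unknown; the two neighbours with the same core give no number, which points toward weak inhibition for compound 4 as well, with a real chance that this assay again reports no number. Compound 4 is therefore expected to come out around 30000 nM, within a range from 5000 nM to 150000 nM.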

Compound 4, half-maximal inhibitory concentration: 45 nM
For compound 4 the middle estimate is 670-fold (2.82 log units) above the measured one; measured number outside the range, below it.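

Compound 2 has no single number in this assay, so no new step can be read from compound 2 to compound 4. The compounds shown leave open how far 3-fluorophenyl in place of 4-acetylphenyl shifts inhibition on this shared core. Nothing measured here offers an explanation for the result.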